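Working notes: a methylthiophene in place of a methylfuran

This account rests on a few compounds, and the source may have more. Where it says the series, first, only, none or still open, it means among the compounds named here.

Among the compounds with values here, in a functional assay on A549 cells (Homo sapiens) for cytotoxicity, read by MTT assay (on this read-out higher numbers stand for weaker inhibition and lower numbers for stronger inhibition), only two compounds have numbers so far. Compound 1 (`COc1ccc(OC)c(C(=O)/C=C/c2ccsc2)c1`) gives 3800 nM, and compound 2 (`COc1ccc(OC)c(C(=O)/C=C/c2ccc(C)o2)c1`) gives 51500 nM, the higher of the two numbers and so the weaker inhibition of the pair.

Still unmeasured is compound 3 (`COc1ccc(OC)c(C(=O)/C=C/c2sccc2C)c1`), with this change from compound 2: 3-methylthiophen-2-yl in place of 5-methylfuran-2-yl on a double-bonded chain carbon bound to a double-bonded chain carbon.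

Within the data shown here, one measured step bears on it: a 14-fold higher number from compound 1 to compound 2 (1.13 log units; beyond the scatter), a large step beyond the scatter, at the same place on the chain. That step replaced thiophen-3-yl with 5-methylfuran-2-yl, and the present change leaves the furan for a thiophene again. Compound 1 is only a partial guide, however, as 3-methylthiophen-2-yl carries a methyl group and a different attachment from thiophen-3-yl. A partial return towards the 3800 nM of compound 1 is therefore expected, not a full one.

In this assay the expected step is a 4.3-fold lower number from compound 2 to compound 3 (0.63 log units; beyond the scatter), towards a lower number and smaller than the measured step. For compound 3 the estimated value is 12000 nM, with an expected range of 3500 nM to 40000 nM.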

Compound 3, half-maximal inhibitory concentration: 22200 nM
Compound 3: the middle estimate sits 1.9-fold (0.27 log units) below what was measured; measured number inside the range.
By their numbers in this assay, from the lowest: compound 1; then compound 3; then compound 2.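

In this assay, a thiophene in place of the furan at this place on the chain wins back only part of the earlier loss: the change gives a 2.3-fold lower number from compound 2 to compound 3 (0.37 log units; beyond the scatter) and is modest, though beyond the scatter. The two thiophenes are also not interchangeable, since 3-methylthiophen-2-yl in place of thiophen-3-yl gives a 5.8-fold higher number from compound 1 to compound 3 (0.77 log units; beyond the scatter), so a sulfur-containing ring alone does not bring the number back to that of compound 1. The order of the three compounds therefore depends on more than the choice between furan and thiophene, and nothing at hand explains these differences.

Compound 3 differs from compound 1 both in its methyl group and in the attachment of the ring, and from compound 2 in the ring atom and in the placing of the methyl group, so the share of each in these steps remains unresolved. Open as well are the numbers that thiophen-2-yl and 5-methylthiophen-2-yl would give here, and whether an amine or a carboxylic acid on the ring would be tolerated at this place.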